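Replacing Chlorophenyl with tert-Butyl on a Hydroxy Acyl Arm

The compounds below may be only part of what the source reports. "The series", "measured", "known", "first", "only" and "open" are said of these compounds alone.

Compound 3, `O=C(NCc1cc(Cl)ccc1-n1cnnn1)[C@@H]1C[C@@H]2C[C@@H]2N1C(=O)[C@H](O)c1cccc(Cl)c1`, stands at the fast end of the numbers shown: in an ADME assay on liver for metabolic stability, with Liver microsome (Homo sapiens) as the target, read by LC-MS, using microsomes (a higher number here means faster removal of the compound, a lower number slower removal), it gives only > 500 mL.min-1.g-1, which is a limit of the assay and not a number. Two related compounds sit at the slow end. Compound 1, `CCCC[C@@H](O)C(=O)N1N=CC[C@H]1C(=O)NCc1cc(Cl)ccc1-n1cnnn1`, gives in this assay a limit of < 12 mL.min-1.g-1. Compound 2, `O=C(NCc1cc(Cl)ccc1-n1cnnn1)[C@@H]1[C@@H]2C[C@@H]2CN1C(=O)[C@H](O)c1ccccc1`, likewise gives a limit, < 15 mL.min-1.g-1. Compound 4, `CC(C)(C)[C@@H](O)C(=O)N1[C@H](C(=O)NCc2cc(Cl)ccc2-n2cnnn2)C[C@@H]2C[C@@H]21`, has not been measured. It differs from compound 3 by tert-butyl in place of 3-chlorophenyl on a saturated chain carbon bound to a carbonyl carbon and an oxygen on a saturated carbon. Going by the values given here, no measured pair shows this exact change, so any expectation rests on the values of compound 1 and compound 2. A large fall in clearance is expected, an at least 20-fold lower number from compound 3 to compound 4 (1.30 log units; beyond the scatter). Compound 4 is estimated at 25 mL.min-1.g-1, in a range from 8 mL.min-1.g-1 to 100 mL.min-1.g-1.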

Compound 4, intrinsic clearance in microsomes: 75 mL.min-1.g-1
Compound 4: the middle estimate sits 3.0-fold (0.48 log units) below what was measured; measured number inside the range.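

In this assay, tert-butyl in place of 3-chlorophenyl gives an at least 6.6-fold lower number from compound 3 to compound 4 (0.82 log units; beyond the scatter), the first direct sign that the group on this carbon strongly affects clearance on this core. Compound 4 is also the only compound shown with a true number rather than a limit. The true size of the step stays unknown, as compound 3 rests on a limit of the assay: the limit of > 500 mL.min-1.g-1 in this assay, at which 1 of the 4 values shown sits.

From the compounds shown here alone, whether the step follows from losing the chlorine or the whole aromatic ring remains open. So does how plain phenyl, cyclohexyl or isopropyl would behave in this place on the same core.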